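Carboxy to phenyl: working notes on compound 3

A few compounds are considered here, and "the series" means these few. Any claim that something is new, unique, unknown or untested is made for them only; others in the source may bear on it.

Measured so far in a functional assay on MCF7 cells (Homo sapiens) for antiproliferative activity; on this read-out higher numbers stand for weaker inhibition and lower numbers for stronger inhibition:
Compound 1 `CC(C)=CCc1cc(C(=O)Nc2cc3ccc(OCC4CCCNC4)c(C)c3oc2=O)ccc1O`: 790 nM
Compound 2 `CC(C)=CCc1cc(C(=O)Nc2cc3ccc(OCCCNCC(=O)O)c(C)c3oc2=O)ccc1O`: 18100 nM

Compound 2, at 18100 nM, has the higher of the two numbers and so the weaker inhibition of the pair. Compound 3 `CC(C)=CCc1cc(C(=O)Nc2cc3ccc(OCCCNCc4ccccc4)c(C)c3oc2=O)ccc1O` is not yet measured. It carries phenyl in place of carboxy on a saturated chain carbon bound to an amine nitrogen, which reads one bond further out as carboxymethyl to benzyl: phenyl in place of carboxy on a saturated chain carbon bound to an amine nitrogen.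

Among the measured compounds shown here, only one measured step bears on this change: a 23-fold higher number from compound 1 to compound 2 (1.36 log units; beyond the scatter), which is large. In that step 2-((carboxymethyl)amino)ethyl replaces piperidin-3-yl, so it removes more than the carboxy alone, and the data do not isolate the contribution of the carboxy. Compound 3 has no carboxy, and neither does compound 1, which gives 790 nM. A clearly lower number is therefore expected in this assay, probably by a step somewhat smaller than the measured one, with wide uncertainty. The step expected is a 10-fold lower number from compound 2 to compound 3 (1.00 log units; beyond the scatter). For compound 3 the estimate is 1800 nM, with an expected range of 500 nM to 7000 nM.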

Compound 3, half-maximal inhibitory concentration: 910 nM
The estimate for compound 3 lay 2.0-fold (0.30 log units) above the measured number, within the range that was stated.
By their numbers in this assay, from the lowest: compounds 1 and 3 (each within the scatter of the next); then compound 2.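

In this assay the change on the saturated chain carbon bound to an amine nitrogen can now be read on its own: phenyl in place of carboxy gives a 20-fold lower number from compound 2 to compound 3 (1.30 log units; beyond the scatter) and so accounts for a large step at this position. The earlier step also exchanged piperidin-3-yl for an open chain, whereas 2-(benzylamino)ethyl in place of piperidin-3-yl gives a 1.2-fold higher number from compound 1 to compound 3 (0.06 log units; within the scatter) and shows that, with phenyl present, the open chain carrying its amine gives a number that cannot be told apart from that of the ring. No measurement on hand bears on the reason for either step.

The compounds shown do not separate the loss of the carboxy from the gain of the phenyl, and a methyl ester, a carboxamide or a plain methyl in the same place would speak to that. On these data alone, it also remains open how the read-out responds to a longer chain between the amine and the phenyl, or to a pyridine ring in place of the phenyl.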